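From compound 1 to compound 4: one exchanged group

This account rests on a few compounds, and the source may have more. Where it says the series, first, only, none or still open, it means among the compounds named here.

Measured so far in a functional assay on CCRF-CEM cells (Homo sapiens) for cytotoxicity, in the absence of a further agent; on this read-out lower numbers stand for stronger inhibition and higher numbers for weaker inhibition:
Compound 1 `COC(=O)c1ccc(CN(CCCc2c(N)nc(N)nc2O)c2cc(F)cc(F)c2[N+](=O)[O-])cc1`: > 100000 nM (a limit)
Compound 2 `Nc1nc(N)c(CCCNc2cc(F)ccc2[N+](=O)[O-])c(O)n1`: > 100000 nM (a limit)
Compound 3 `CC(C)(C)OC(=O)CCC(Nc1ccc(CN(CCCc2c(N)nc(N)nc2O)c2cc(F)c([N+](=O)[O-])cc2[N+](=O)[O-])cc1)C(=O)OC(C)(C)C`: 3100 nM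

Compound 1 gives no number, only the limit > 100000 nM. It sits at the limit of > 100000 nM in this assay, at which 2 of the 3 values shown sit. For the measured compounds named here, compound 3 is the only one with a true number, at 3100 nM.

Compound 4 `COC(=O)c1ccc(CN(CCCc2c(N)nc(N)nc2O)c2cc(F)c(F)cc2[N+](=O)[O-])cc1` keeps the rest of compound 1 and places 4,5-difluoro-2-nitrophenyl in place of 3,5-difluoro-2-nitrophenyl on an amine nitrogen. Going by the values given here, no measured pair differs in one place only, so the data give no direct size for such a step in this assay. A moderate move toward stronger inhibition is expected, though the result may again be only a limit. Compound 3, at 3100 nM, shows that a number can be reached among these compounds, but it differs from compound 1 in several places. The expected change is an at least 3.3-fold lower number from compound 1 to compound 4 (0.52 log units; beyond the scatter). For compound 4 the estimated value is 30000 nM, with an expected range from 6000 nM to 100000 nM.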

Compound 4, half-maximal inhibitory concentration: 59000 nM
Compound 4: middle estimate off by 2.0-fold (0.29 log units), on the low side, within the range that was stated.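

In this assay, compound 1 gives only a limit, > 100000 nM. With the same atoms joined differently, 4,5-difluoro-2-nitrophenyl in place of 3,5-difluoro-2-nitrophenyl on the amine nitrogen gives a true value for compound 4, and the change reads as an at least 1.6-fold lower number from compound 1 to compound 4 (0.22 log units; that floor lies within the scatter). Moving a fluorine on this ring is thus enough to bring a number within reach, but only a floor can be read for the step, so its true size stays unknown: the limit of > 100000 nM in this assay, at which 2 of the 4 values shown sit.

The compounds shown leave open whether this exchange would act the same way with a carboxylic acid in place of the methyl ester. They also do not show what a single change would do if an amine took the place of a fluorine on this ring.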